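A ring-bound acid replaces the open chain of compound 2

The source may report more compounds than this note shows. Statements on the series, on what has been measured and on what is new or still open speak of the compounds shown alone.

In a functional assay on NCI-H929 cells (Homo sapiens) for antiproliferative activity, with a stated time of 24 h (a lower number here means a stronger inhibitor, a higher number a weaker inhibitor), compound 1 (`COc1ccc(F)cc1-c1ccnc2[nH]c(C3=CCC(NCC(=O)O)CC3)cc12`) gives 450 nM and compound 2 (`COc1ccc(F)cc1-c1ccnc2[nH]c(C3=CCC(N[C@@H](C(=O)O)C(C)C)CC3)cc12`) gives 76 nM as the lower of the two numbers. For the measured compounds named here, the one measured step is a 5.9-fold lower number from compound 1 to compound 2 (0.77 log units; beyond the scatter) and comes with isopropyl in place of hydrogen on a saturated chain carbon. Compound 3 (`COc1ccc(F)cc1-c1ccnc2[nH]c(C3=CCC(N4CCC(C(=O)O)CC4)CC3)cc12`) carries 4-carboxypiperidin-1-yl in place of (1-carboxy-2-methylpropyl)amino on a saturated ring carbon. Going by the values given here, that exchange removes the isopropyl group, and no measured compound yet shows what the new ring does. Part of a 5.9-fold lower number from compound 1 to compound 2 (0.77 log units; beyond the scatter) is therefore expected to be lost, which points to a modest move toward a higher number in this assay rather than a large one. The expected change is a 2.5-fold higher number from compound 2 to compound 3 (0.40 log units; beyond the scatter) in this estimate. For compound 3 the estimated value is 190 nM with an expected range from 60 nM to 600 nM at this stage.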

Compound 3, half-maximal inhibitory concentration: 170 nM
For compound 3 the middle estimate is 1.1-fold (0.05 log units) above the measured one; low and high end bracket the measured number.
By their numbers in this assay, from the lowest: compound 2; then compound 3; then compound 1.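

On this saturated ring carbon, the step with a 2.2-fold higher number from compound 2 to compound 3 (0.35 log units; beyond the scatter) in this assay shows that replacing the open (1-carboxy-2-methylpropyl)amino chain with 4-carboxypiperidin-1-yl costs some activity, but does not abolish it. The same ring also improves on the smaller open chain, with a 2.6-fold lower number from compound 1 to compound 3 (0.42 log units; beyond the scatter) as the step from (carboxymethyl)amino, so a lower number than that of compound 1 does not depend on the isopropyl group alone. No available evidence explains either step.

The compounds shown leave open whether an isopropyl or methyl group on the ring of 4-carboxypiperidin-1-yl would recover the number of compound 2. They also leave open how a four- or five-membered ring carrying the carboxylic acid, or a primary amide in place of that acid, would behave at this position.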